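This account rests on a few compounds, and the source may have more. Where it says the series, first, only, none or still open, it means among the compounds named here.

Compound 1 `CCCSc1nc(=O)ccn1[C@@H]1O[C@H](COP(=O)(O)OP(=O)(O)O)[C@@H](O)[C@H]1O` gives 4900 nM in an in vitro functional assay on 1321-N1 cells for agonist activity at P2Y purinoceptor 4 (Homo sapiens), read by scintillation proximity assay and inositol phosphate accumulation; a lower number here means that less compound is needed, a higher number that more compound is needed for the effect. Compound 2 `O=c1ccn([C@@H]2O[C@H](COP(=O)(O)O)[C@@H](O)[C@H]2O)c(SCc2ccccc2)n1` reaches only the limit of this assay and is reported as > 100000 nM, which is a limit rather than a measured number (the limit of > 100000 nM in this assay, at which 1 of the 2 values shown sits). Compound 3 `CCCSc1nc(=O)ccn1[C@@H]1O[C@H](COP(=O)(O)O)[C@@H](O)[C@H]1O` is compound 2 with ethyl in place of phenyl on a saturated chain carbon bound to a sulfur. Because compound 2 sits at a limit, the size of the step from compound 2 to compound 3 in this assay is hard to judge, but a small gain is expected, an at least 1.6-fold lower number from compound 2 to compound 3 (0.22 log units; that floor lies within the scatter). Compound 3 is expected to give about 60000 nM in this assay, in a range from 10000 nM to 300000 nM.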

Compound 3, half-maximal effective concentration: > 100000 nM
Compound 3 was reported as a limit; the forecaster's own chance of this, stated with the estimate: 55%; at least 1.6-fold (0.22 log units) between middle value and limit.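

With propylsulfanyl held fixed, a hydrogen atom in place of the outer group of one phosphorus and three oxygen atoms gives an at least 20-fold higher number from compound 1 to compound 3 (1.30 log units; beyond the scatter), so this end of the molecule has a large effect on the number. Swapping benzylsulfanyl for propylsulfanyl cannot be read here, because compound 2 and compound 3 are both reported only as limits: the limit of > 100000 nM in this assay, at which 2 of the 3 values shown sit.

Still open, going by these compounds, is how benzylsulfanyl and propylsulfanyl compare when the outer group is present. Also open, on these data alone, is whether a longer chain on the sulfur, such as butyl, would change the number.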